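Replacing ethyl by hydroxy on the phenyl ring

This account rests on a few compounds, and the source may have more. Where it says the series, first, only, none or still open, it means among the compounds named here.

Compound 1 `Cc1nc(-c2cnc3ccc(-c4ccc(O)cc4)cc3c2)no1` gives only the limit > 2500 nM in a functional assay on RD cells (Homo sapiens) for inhibition, read by luminescence and ATP content, with a stated time of 72 h; on this read-out lower numbers stand for higher toxicity in this test and higher numbers for lower toxicity in this test.
Compound 2 `CCc1nc(-c2cnc3ccc(-c4ccc(N)nc4)cc3c2)no1` gives only the limit > 66700 nM in this assay.
Compound 3 `CCc1ccc(-c2ccc3ncc(-c4noc(CC)n4)cc3c2)cc1` gives only the limit > 22200 nM in this assay.

Compound 3 thus stands nowhere precisely: it shows a limit, and the two other values shown are limits as well. For the measured compounds named here, the single measured step in this set, a step that the two limits leave unreadable from compound 2 to compound 3, is therefore unreadable. The change to the unmeasured compound 4 `CCc1nc(-c2cnc3ccc(-c4ccc(O)cc4)cc3c2)no1` is hydroxy in place of ethyl on an aromatic carbon. Going by the values given here, what the data offer on this is the limit of > 22200 nM in this assay, at which 1 of the 3 values shown sits, the limit of > 2500 nM in this assay, at which 1 of the 3 values shown sits, and (the limit of > 66700 nM in this assay, at which 1 of the 3 values shown sits); none of them is a number, so no measured step gives a size or direction for the change. Compound 1, which also carries the 4-hydroxyphenyl group, reached only its limit in this assay. For compound 4 an outcome at or beyond the limit is expected, about 30000 nM, with a range from 5000 nM to 100000 nM. That expectation corresponds to a step that the limit leaves unreadable from compound 3 to compound 4, not readable beyond the scatter.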

Compound 4, half-maximal cytotoxic concentration: > 2500 nM
Compound 4: only a limit was reported; the forecaster's own chance of this, stated with the estimate: 80%; the middle value is on the limit's open side.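

In this assay compound 4 gives > 2500 nM which is a limit, not a number. Its steps from compound 1, compound 2 and compound 3 therefore cannot be read. The compounds shown leave open at what concentration any of them becomes toxic to these cells.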